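A Longer Chain on Compound 1

A few compounds are considered here, and "the series" means these few. Any claim that something is new, unique, unknown or untested is made for them only; others in the source may bear on it.

In a functional assay on UACC-62 cells (Homo sapiens) for cytotoxicity (on this read-out higher numbers stand for weaker inhibition of growth and lower numbers for stronger inhibition of growth), compound 1 `CCCCCCNC(=O)c1cc(NCc2cc(O)ccc2O)ccc1O` gives 12000 nM and compound 2 `O=C(NCc1ccccc1)c1cc(NCc2cc(O)ccc2O)ccc1O` gives 15000 nM on the same read-out. The step of a 1.3-fold higher number from compound 1 to compound 2 (0.10 log units; within the scatter) leaves these two level. Compound 3 `CCCCCCCCCCCCNC(=O)c1cc(NCc2cc(O)ccc2O)ccc1O` carries hexyl in place of hydrogen on a saturated chain carbon, six bonds along the chain from an amide-type nitrogen on the chain of compound 1, that is, hexyl in place of hydrogen. Going by the values given here, the one measured step swaps one group for another and does not test chain length, so it is only a weak guide. As far as these compounds go, no change beyond the scatter is therefore expected in this assay, and either direction stays open. The estimated change is a 1.2-fold lower number from compound 1 to compound 3 (0.08 log units; within the scatter) and no more. Compound 3 is expected near 10000 nM with 3000 nM to 30000 nM as its estimated range.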

Compound 3, concentration for 50% growth inhibition: 3200 nM
Estimate against measurement, compound 3: 3.1-fold (0.49 log units) above; low and high end bracket the measured number.
By their numbers in this assay, from the lowest: compound 3; then compounds 1 and 2 (each within the scatter of the next).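

In this assay, hexyl in place of hydrogen gives a 3.8-fold lower number from compound 1 to compound 3 (0.57 log units; beyond the scatter) and so moves the number towards stronger inhibition of growth. The earlier change, a 1.3-fold higher number from compound 1 to compound 2 (0.10 log units; within the scatter), did not move the number beyond the scatter, so this chain carbon is the first place shown to respond. Nothing measured here explains the shift. The compounds shown leave open whether a longer chain would lower the number further. They also leave open whether a chain ending in an amine or a carboxylic acid would behave like this one.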